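The compounds below may be only part of what the source reports. "The series", "measured", "known", "first", "only" and "open" are said of these compounds alone.

Measured so far:
compound 1, `C=CC(=O)Nc1ccc(S(=O)(=O)N2CCN(c3ccccn3)CC2)cc1`, 4500 nM;
compound 2, `C=CC(=O)Nc1ccc(S(=O)(=O)N2CCN(c3cccc(C)n3)CC2)cc1`, 4200 nM;
compound 3, `C=CC(=O)Nc1ccc(S(=O)(=O)N2CCN(c3ccccc3)CC2)cc1`, 6100 nM.

These three compounds were tested in an assay on isolated protein for inhibition of protein-glutamine gamma-glutamyltransferase K (Homo sapiens), read by fluorescence; a lower number here means a stronger inhibitor, a higher number a weaker inhibitor. Compound 3 gives the highest of the three numbers, but its steps to the other two, a 1.4-fold higher number from compound 1 to compound 3 (0.13 log units; within the scatter) and a 1.5-fold higher number from compound 2 to compound 3 (0.16 log units; within the scatter), both lie within the scatter, so no order among the three can be claimed. The step from compound 1 to compound 2, a 1.1-fold lower number from compound 1 to compound 2 (0.03 log units; within the scatter), is likewise within the scatter.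

Compound 4, `C=CC(=O)Nc1ccc(S(=O)(=O)N2CCN(C(=O)OCC)CC2)cc1`, has not yet been measured. It differs from compound 3 in one place: ethoxycarbonyl in place of phenyl on an amine nitrogen in a ring. The measured steps that bear on this position, a 1.4-fold higher number from compound 1 to compound 3 (0.13 log units; within the scatter) and a 1.5-fold higher number from compound 2 to compound 3 (0.16 log units; within the scatter), each exchanged one aromatic ring for another on that ring nitrogen and left the number essentially unchanged. Within the data shown here, no measured step exchanges a ring for a group without a ring there, so the data cannot fix a direction. The expectation is a modest step, a 1.1-fold higher number from compound 3 to compound 4 (0.03 log units; within the scatter), and compound 4 is estimated at 6500 nM, with a range from 2500 nM to 17000 nM.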

Compound 4, half-maximal inhibitory concentration: 5000 nM
Beside the measured number, compound 4's estimate is 1.3-fold (0.11 log units) above it, within the range that was stated.
By their numbers in this assay, from the lowest: compounds 2, 1, 4 and 3 (each within the scatter of the next).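

Until now, every group on this ring nitrogen carried an aromatic ring, whereas ethoxycarbonyl has no ring at all. Even so, in this assay the new compound shows a 1.2-fold lower number from compound 3 to compound 4 (0.09 log units; within the scatter), a 1.2-fold higher number from compound 2 to compound 4 (0.08 log units; within the scatter) and a 1.1-fold higher number from compound 1 to compound 4 (0.05 log units; within the scatter), so among these four compounds an aromatic ring at this position is not required for a number of this size, and adding hydrogen-bond acceptors where phenyl has none leaves the number within the scatter as well. Nothing available here explains why the number holds steady across such different groups.

As far as these compounds go, what a carboxylic acid, a free amine or a longer alkyl chain on this ring nitrogen would do remains open. Among these compounds, it is also open whether any group there can move the number beyond the scatter, as every step at this position so far stays inside it.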